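This account rests on a few compounds, and the source may have more. Where it says the series, first, only, none or still open, it means among the compounds named here.

In a functional assay on CCRF-CEM cells (Homo sapiens) for inhibition, read by MTT assay, with a stated time of 72 h (a lower number here means a stronger inhibitor, a higher number a weaker inhibitor), compound 1 `C=C(Br)C(=O)Nc1cccc(/C=C/C(=O)Nc2ccccc2)c1` gives 190 nM and compound 2 `C=C(Br)C(=O)Nc1cccc(/C=C/C(=O)Nc2ccc(OCC)cc2)c1` gives 98 nM, which is a 1.9-fold lower number from compound 1 to compound 2 (0.29 log units; within the scatter). Compound 3 `C=C(Br)C(=O)Nc1cccc(/C=C/C(=O)Nc2ccc(OC(F)(F)F)cc2)c1` is the weakest of the three at 13000 nM, with a 68-fold higher number from compound 1 to compound 3 (1.84 log units; beyond the scatter) and a 130-fold higher number from compound 2 to compound 3 (2.12 log units; beyond the scatter). Compound 4 `C=C(Br)C(=O)Nc1cccc(/C=C/C(=O)Nc2ccc(SC(F)(F)F)cc2)c1` changes one group of compound 3: (trifluoromethyl)sulfanyl in place of trifluoromethoxy on an aromatic carbon. Among the compounds with values here, no measured step trades oxygen for sulfur, so the evidence is indirect. The large steps into compound 3 show that this ring position can move the number far, yet the ethoxy step stayed small. Since the trifluoromethyl part stays in place, little change is expected, in neither direction particularly. The estimated step is a 1.3-fold lower number from compound 3 to compound 4 (0.11 log units; within the scatter). Compound 4 is expected at 10000 nM, within an estimated range of 3000 nM to 30000 nM.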

Compound 4, half-maximal inhibitory concentration: 15300 nM
Beside the measured number, compound 4's estimate is 1.5-fold (0.18 log units) below it; the measured number falls inside the stated range.
By their numbers in this assay, from the lowest: compounds 2 and 1 (each within the scatter of the next); then compounds 3 and 4 (each within the scatter of the next).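

In this assay, trading the oxygen of trifluoromethoxy for the sulfur of (trifluoromethyl)sulfanyl leaves the number in place (a 1.2-fold higher number from compound 3 to compound 4 (0.07 log units; within the scatter)), so the weak result at this ring position does not depend on that oxygen. The sulfur compound sits as far from the other two as compound 3 does (a 160-fold higher number from compound 2 to compound 4 (2.19 log units; beyond the scatter); an 81-fold higher number from compound 1 to compound 4 (1.91 log units; beyond the scatter)). No measurement shown here explains this gap.

On these data alone, whether the trifluoromethyl part itself carries the loss stays open. A methoxy group, a longer alkoxy chain or an amine at this place could help to show where weak turns to strong.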